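Isopropyl for propyl on the amide nitrogen

This account rests on a few compounds, and the source may have more. Where it says the series, first, only, none or still open, it means among the compounds named here.

Measured so far:
- compound 1, `O=C(C1CC1)[C@H]1C[C@@H]2CNC[C@@H](C2)C1`: 4100 nM in an assay on CHO cells for displacement of a labelled ligand from Neuronal acetylcholine receptor; alpha3/beta4 (Homo sapiens), read by scintillation counting, with a stated time of 2 h; a lower number here means a stronger inhibitor, a higher number a weaker inhibitor
- compound 2, `CCCNC(=O)[C@H]1C[C@@H]2CNC[C@@H](C2)C1`: 4000 nM in this assay

Compound 2 and compound 1 sit close together: the step of a 1.0-fold lower number from compound 1 to compound 2 (0.01 log units; within the scatter) shows that swapping the cyclopropyl ketone for a propyl amide left the number essentially unchanged. Compound 3, `CC(C)NC(=O)[C@H]1C[C@@H]2CNC[C@@H](C2)C1`, keeps the same atoms as compound 2 and differs only in how they are joined: isopropyl in place of propyl on an amide-type nitrogen. Among the measured compounds shown here, no measured step tests branching of the chain on the amide nitrogen; the one step available, a 1.0-fold lower number from compound 1 to compound 2 (0.01 log units; within the scatter), concerns a different kind of change and was itself within the scatter. Nothing in the data therefore points to a move in either direction. Compound 3 is expected to give about 4000 nM in this assay, with a range from 1500 nM to 11000 nM. The estimated step of no change at the digits printed from compound 2 to compound 3 (within the scatter) is expected to stay within the scatter.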

Compound 3, inhibition constant: 6000 nM
The estimate for compound 3 lay 1.5-fold (0.18 log units) below the measured number; the measured number falls inside the stated range.
By their numbers in this assay, from the lowest: compounds 2, 1 and 3 (each within the scatter of the next).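

Branching the chain on the amide nitrogen now has a direct test in this assay: the step, a 1.5-fold higher number from compound 2 to compound 3 (0.18 log units; within the scatter), shows that the propyl and isopropyl amides cannot be told apart here. Replacing the cyclopropyl on the carbonyl carbon with isopropylamino gives the same picture, with a 1.5-fold higher number from compound 1 to compound 3 (0.17 log units; within the scatter), so the three groups compared so far on this carbonyl carbon all read alike within the scatter. No measurement is available to explain these readings.

On these data alone, whether a longer chain such as butyl, or a bulkier group such as tert-butyl or benzyl, on the amide nitrogen would shift the number beyond the scatter remains open. As far as these compounds go, it is also open whether a carboxylic acid or a methyl ester in place of these amides would read differently.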